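From Isopropyl to Butyl on an Amine Nitrogen

A few compounds are considered here, and "the series" means these few. Any claim that something is new, unique, unknown or untested is made for them only; others in the source may bear on it.

Measured so far in a functional assay on the whole organism for inhibition, with Mus musculus as the target; a lower number here means that less compound is needed, a higher number that more compound is needed for the effect:
Compound 1 `CCCNC(=O)Nc1cccc2c1CN(C)CC2c1ccccc1`: > 80 mg/kg (a limit, not a number)
Compound 2 `CCOC(=O)Nc1cccc2c1CN(C)CC2c1ccccc1`: 3.2 mg/kg
Compound 3 `CC(C)NCCC(=O)Nc1cccc2c1CN(C)CC2c1ccccc1`: 150 mg/kg

Compound 3 holds the higher of the two true numbers, with a 47-fold higher number from compound 2 to compound 3 (1.67 log units; beyond the scatter). Compound 4 `CCCCNCCC(=O)Nc1cccc2c1CN(C)CC2c1ccccc1` carries butyl in place of isopropyl on an amine nitrogen. That step and an at least 25-fold lower number from compound 1 to compound 2 (1.39 log units; beyond the scatter) are both large, but each swaps the group on a carbonyl carbon, which compound 4 leaves unchanged. Among the compounds with values here, no measured step tests the amine nitrogen, so no change beyond the scatter is expected in this assay. The expected outcome is a 1.2-fold lower number from compound 3 to compound 4 (0.06 log units; within the scatter). For compound 4 the estimate is 130 mg/kg, with an expected range from 45 mg/kg to 350 mg/kg.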

Compound 4, dose for half-maximal effect: about 46 mg/kg
Beside the measured number, compound 4's estimate is 2.8-fold (0.45 log units) above it; the measured number falls inside the stated range.
By their numbers in this assay, from the lowest: compound 2; then compound 4; then compound 3.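

In this assay, the amine nitrogen now has a measured step of its own (a 3.3-fold lower number from compound 3 to compound 4 (0.51 log units; beyond the scatter)), showing that butyl in place of isopropyl can move the dose needed, though only modestly. This change still leaves a much larger gap to the ethoxy group on the carbonyl carbon (a 14-fold higher number from compound 2 to compound 4 (1.16 log units; beyond the scatter)). Compound 1 has a limit, not a number, so its step gives only a floor (an at least 1.7-fold lower number from compound 1 to compound 4 (0.24 log units; that floor lies within the scatter)): the limit of > 80 mg/kg in this assay, at which 1 of the 4 values shown sits.

On these data alone, whether a longer chain such as hexyl or a ring such as cyclohexyl on this amine nitrogen would lower the number further remains open.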